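The source may report more compounds than this note shows. Statements on the series, on what has been measured and on what is new or still open speak of the compounds shown alone.

Of the compounds shown here, two with a shared core have been measured in a functional assay on A549 cells (Homo sapiens) for inhibition, read by MTT assay, with a stated time of 72 h; on this read-out higher numbers stand for weaker inhibition and lower numbers for stronger inhibition. Compound 1 `Cc1cc2occ(-c3nc(-c4ccccc4)c(-c4ccccc4)n3-c3cccc([N+](=O)[O-])c3)c(=O)c2cc1Cl` gives 6250 nM, while compound 2 `Cc1cc2occ(-c3nc(-c4ccccc4)c(-c4ccccc4)n3-c3ccc(Br)cc3)c(=O)c2cc1Cl` stands at the higher, weaker end of the pair with 25000 nM. The two differ only in the group on an aromatic nitrogen, and the measured change is a 4.0-fold higher number from compound 1 to compound 2 (0.60 log units; beyond the scatter), a modest step beyond the usual scatter.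

Compound 3 `COc1cccc(-n2c(-c3coc4cc(C)c(Cl)cc4c3=O)nc(-c3ccccc3)c2-c2ccccc2)c1` has not yet been measured. It carries 3-methoxyphenyl in place of 4-bromophenyl on that same aromatic nitrogen: 3-methoxyphenyl in place of 4-bromophenyl on an aromatic nitrogen.

Going by the values given here, only one measured step bears on this change, the one at the same place in compound 1, where 3-nitrophenyl came with the lower number in a 4.0-fold higher number from compound 1 to compound 2 (0.60 log units; beyond the scatter). Methoxy is not nitro, so this single step is only a thin guide. Some shift towards stronger inhibition is expected, but probably a smaller one than that measured step. The expected change is a 2.0-fold lower number from compound 2 to compound 3 (0.30 log units; within the scatter). For compound 3 the estimated value in this assay is 12500 nM, with an expected range from 5000 nM to 30000 nM.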

Compound 3, half-maximal inhibitory concentration: 6250 nM
Compound 3: the middle estimate sits 2.0-fold (0.30 log units) above what was measured; the measured number falls inside the stated range.
By their numbers in this assay, from the lowest: compounds 1 and 3 (each within the scatter of the next); then compound 2.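

In this assay, the swap of 4-bromophenyl for 3-methoxyphenyl on the aromatic nitrogen gives a 4.0-fold lower number from compound 2 to compound 3 (0.60 log units; beyond the scatter) and so shows that the earlier shift at this position was not unique to 3-nitrophenyl. Methoxy in place of nitro on an aromatic carbon gives no change at the digits printed from compound 1 to compound 3 (within the scatter), so this assay does not separate these two groups, and compound 2 remains the weakest of the three, with steps to both others beyond the scatter. No measurement of any property of these groups is available to explain these numbers.

The step from compound 2 to compound 3 changes both the group and its place on the phenyl ring, so the compounds shown cannot tell which of the two matters, or whether the bromine itself goes with the higher number. Going by these compounds, how an amine, a carboxylic acid or a longer chain such as an ethoxy group on this phenyl ring would fare also stays open, as does whether the close agreement of methoxy and nitro would hold for any other group.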